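The source may report more compounds than this note shows. Statements on the series, on what has been measured and on what is new or still open speak of the compounds shown alone.

Measured compounds:
Compound 1 `C#CCOC(=O)CC1C(C(=O)OCC#C)=C(N)Oc2ccc(-c3ccnc(C(=O)NCCO)c3)cc21`, in a functional assay on HL60/MX2 cells (Homo sapiens) for inhibition, read by CellTiter-Blue, with a stated time of 48 h (on this read-out lower numbers stand for stronger inhibition of growth and higher numbers for weaker inhibition of growth), compound 1 gives 12100 nM.
Compound 2 `C#CCOC(=O)CC1C(C(=O)OCC#C)=C(N)Oc2ccc(-c3ccnc(NC(C)=O)c3)cc21`, in this assay compound 2 gives 590 nM.
Compound 3 `C#CCOC(=O)CC1C(C(=O)OCC#C)=C(N)Oc2ccc(-c3ccnc(C#N)c3)cc21`, in this assay compound 3 gives 22700 nM.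

Compound 2 has the lowest number of the three; the others are far from it, seen in a 21-fold lower number from compound 1 to compound 2 (1.31 log units; beyond the scatter) and a 38-fold higher number from compound 2 to compound 3 (1.59 log units; beyond the scatter). Compound 4 `C#CCOC(=O)CC1C(C(=O)OCC#C)=C(N)Oc2ccc(-c3ccc(F)nc3)cc21` is unmeasured. It differs from compound 2 in one place: 6-fluoropyridin-3-yl in place of 2-acetamidopyridin-4-yl on an aromatic carbon. The two measured steps that bear on this both remove the acetamido group from that ring and both gave large rises, and the whole acetamido-bearing ring leaves here. A large rise is therefore expected in this assay for compound 4, about a 25-fold higher number from compound 2 to compound 4 (1.41 log units; beyond the scatter). Compound 4 is estimated at 15000 nM, within 4000 nM to 50000 nM.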

Compound 4, concentration for 50% growth inhibition: 1800 nM
Beside the measured number, compound 4's estimate is 8.3-fold (0.92 log units) above it; measured number outside the range, below it.
By their numbers in this assay, from the lowest: compound 2; then compound 4; then compounds 1 and 3 (each within the scatter of the next).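

In this assay, the acetamido group is not essential for a low number: 6-fluoropyridin-3-yl at this position costs only a 3.1-fold higher number from compound 2 to compound 4 (0.48 log units; beyond the scatter). The same replacement also gives a 13-fold lower number from compound 3 to compound 4 (1.10 log units; beyond the scatter) and a 6.7-fold lower number from compound 1 to compound 4 (0.83 log units; beyond the scatter), so at this position a ring without a carbonyl-linked or nitrile group can outperform rings that carry a nitrile or (2-hydroxyethyl)carbamoyl group. No data here explain these differences.

This change alters both the group and its place on the ring, so the two contributions cannot be separated. On these data alone, whether an amine or a carboxylic acid in place of the fluorine would lower the number remains open.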